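This account rests on a few compounds, and the source may have more. Where it says the series, first, only, none or still open, it means among the compounds named here.

Series notes. Compound 1 `CC(C)[C@@H]1CC[C@@H](C)C[C@@]12N(C)C(=O)[C@@H]1[C@H]3C(=O)NC(=O)[C@H]3ON12`, compound 2 `CC(C)[C@@H]1CC[C@@H](C)C[C@@]12N(C)C(=O)[C@@H]1[C@H]3C(=O)N(C)C(=O)[C@H]3ON12` and compound 3 `COc1ccc(N2C(=O)[C@H]3[C@H](ON4[C@@H]3C(=O)N(C)[C@@]43C[C@H](C)CC[C@H]3C(C)C)C2=O)cc1` share one core and differ only on an amide-type nitrogen in a ring. In a functional assay, read by spectrophotometry, with a stated time of 2 h, tested at 1 mg/mL (a higher number here means a stronger effect of the compound at the concentration tested, a lower number a weaker effect), compound 1 gives 35.6%, compound 2 gives 47.7% and compound 3 gives 50%, the highest of the three numbers, though its gap to compound 2 lies within the scatter. The steps were a number 12.1 percentage points higher from compound 1 to compound 2 (beyond the scatter), a number 14.4 percentage points higher from compound 1 to compound 3 (beyond the scatter) and a number 2.3 percentage points higher from compound 2 to compound 3 (within the scatter). Compound 4 `Cc1ccc(N2C(=O)[C@H]3[C@H](ON4[C@@H]3C(=O)N(C)[C@@]43C[C@H](C)CC[C@H]3C(C)C)C2=O)c(C)c1` differs from compound 3 as follows: 2,4-dimethylphenyl in place of 4-methoxyphenyl on an amide-type nitrogen in a ring. Going by the values given here, no measured step exchanges one substituted phenyl for another; the nearest step, a number 2.3 percentage points higher from compound 2 to compound 3 (within the scatter), stayed within the scatter. A step of no more than the scatter is therefore expected in this assay, so for compound 4 the estimate is 48%, between 35% and 61%, an expected step of a number 2 percentage points lower from compound 3 to compound 4 (within the scatter).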

Compound 4, a percentage reported as activity, at one concentration (the size of the read-out at that concentration, not a potency): 53.1%
Compound 4: the middle estimate sits 5.1 percentage points below what was measured, and the stated range covers the measured number.
By their numbers in this assay, from the lowest: compound 1; then compounds 2, 3 and 4 (each within the scatter of the next).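

In this assay the 2,4-dimethylphenyl for 4-methoxyphenyl exchange, which drops the hydrogen-bond acceptor of the leaving group, gives a number 3.1 percentage points higher from compound 3 to compound 4 (within the scatter) as a direct reading of one substituted phenyl against another on this nitrogen. The same group gives a number 5.4 percentage points higher from compound 2 to compound 4 (within the scatter) against methyl and a number 17.5 percentage points higher from compound 1 to compound 4 (beyond the scatter) against hydrogen, so among these four compounds only compound 1, with the amide hydrogen, stands apart. Nothing available explains these numbers.

On these data alone, whether a carboxylic acid or a longer chain bearing an amine on this nitrogen would give a number beyond the scatter of compounds 2, 3 and 4 remains open. So does the standing of an unsubstituted phenyl.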